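Lengthening the Saturated Chain of Compound 2

A few compounds are considered here, and "the series" means these few. Any claim that something is new, unique, unknown or untested is made for them only; others in the source may bear on it.

Measured compounds, with values from a functional assay on SW480 cells (Homo sapiens) for antiproliferative activity, read by MTT assay, with a stated time of 48 h (a higher number here means a weaker inhibitor, a lower number a stronger inhibitor), given below
compound 1 `CCCCC(CCO)n1cnc2c(OC)ncnc21` gives > 50000 nM
compound 2 `CCCCCCCCC(CCO)n1cnc2c(OC)ncnc21` gives 24600 nM
compound 3 `CCCCCCCCC(CCO)n1cnc2c(NC)ncnc21` gives 3770 nM

The reading for compound 1 of > 50000 nM is a limit of the assay and not a number. Compound 2, at 24600 nM in this assay, holds the higher of the two actual numbers, and the nearest of them lies at a 6.5-fold lower number from compound 2 to compound 3 (0.81 log units; beyond the scatter) on swapping methoxy for methylamino.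

Compound 4 `CCCCCCCCCCC(CCO)n1cnc2c(OC)ncnc21` keeps the methoxy group and the core of compound 2 and carries ethyl in place of hydrogen on a saturated chain carbon, nine bonds along the chain from an aromatic nitrogen. Among the measured compounds shown here, the closest precedent is an at least 2.0-fold lower number from compound 1 to compound 2 (0.30 log units; that floor lies within the scatter), which also extends this chain and rests on (the limit of > 50000 nM in this assay, at which 1 of the 3 values shown sits), so it gives a floor and not a size. The methylamino step changes another place and does not bear on this one. A small further move toward a lower number is therefore expected, possibly no larger than the scatter. The estimate amounts to a 2.2-fold lower number from compound 2 to compound 4 (0.35 log units; beyond the scatter) as the expected step. For compound 4 the expected value is 11000 nM, with an estimated range from 3500 nM to 35000 nM.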

Compound 4, half-maximal inhibitory concentration: 8260 nM
Estimate against measurement, compound 4: 1.3-fold (0.12 log units) above; the range from low to high includes it.
By their numbers in this assay, from the lowest: compound 3; then compound 4; then compound 2. At a limit, above all of these: compound 1.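

In this assay, among the compounds shown here, a 3.0-fold lower number from compound 2 to compound 4 (0.47 log units; beyond the scatter), and this is the first extension of the saturated chain with a measured number at both ends, so the change now has a size, and that size lies beyond the scatter, where the earlier step along this chain gave only a floor that lay within it. Across the three compounds that carry methoxy, compound 1, compound 2 and compound 4, the longer chain goes with the lower number, and none of the three goes against that order, although one end of it is a limit and the pattern rests on these compounds alone. The full change in chain length, an at least 6.0-fold lower number from compound 1 to compound 4 (0.78 log units; beyond the scatter), gives a floor beyond the scatter and not a size, since it starts from a limit and not a number: the limit of > 50000 nM in this assay, at which 1 of the 4 values shown sits.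

The compounds shown leave open whether a longer chain than that of compound 4 would lower the number further or whether the trend stops there. They also leave open whether methylamino in place of methoxy on the chain of compound 4 would give a step like the one seen on the chain of compound 2, and what a carboxylic acid in place of the hydroxyl group would do.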